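The source may report more compounds than this note shows. Statements on the series, on what has been measured and on what is new or still open speak of the compounds shown alone.

Measured so far:
- compound 1, `C/N=C(/S)C1(c2cccnc2)CCCCC1=O`: 800 nM
- compound 2, `C/N=C(/S)[C@@]1(c2cccnc2)CCCC[C@@H]1CCN`: 10000 nM

In a functional assay (aorta) with Rattus norvegicus as the target (on this read-out higher numbers stand for weaker inhibition and lower numbers for stronger inhibition), compound 1 gives 800 nM and compound 2 gives 10000 nM. Compound 2 therefore has the higher of the two numbers, and the gap to compound 1 is beyond the usual scatter, so compound 2 is the weaker of the pair on this read-out. The two structures differ in more than one place, so nothing is inferred about which part of that difference carries the gap.

Compound 3, `C/N=C(/S)[C@@]1(c2cccnc2)CCCC[C@@H]1CCNS(C)(=O)=O`, is the next step from compound 2. The change is methylsulfonyl in place of hydrogen on an amine nitrogen; it sits on the amine nitrogen whose other neighbour is a saturated chain carbon. For the measured compounds named here, no measured pair shows this change, so there is no prior step to lean on. The expectation is for a small step from compound 2 to compound 3 in this assay, a 1.3-fold lower number from compound 2 to compound 3 (0.10 log units; within the scatter), not clearly beyond the scatter in either direction. Compound 3 is estimated at 8000 nM, with a range of 2000 nM to 30000 nM.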

Compound 3, concentration for 90% inhibition: 170 nM
Compound 3: middle estimate off by 47-fold (1.67 log units), on the high side, and the stated range ends above it.
By their numbers in this assay, from the lowest: compound 3; then compound 1; then compound 2.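

Methylsulfonyl in place of hydrogen on the amine nitrogen gives a 59-fold lower number from compound 2 to compound 3 (1.77 log units; beyond the scatter) in this assay, the first change in the series that can be read at a single place. This marks the amine nitrogen whose other neighbour is a saturated chain carbon as a position where the read-out responds strongly to what is attached, and with compound 3 at 170 nM, the free 2-aminoethyl group is shown not to be needed for a low number in this assay. No measurement at hand bears on why this step is so large.

The compounds shown leave open whether the step belongs to the sulfonyl group itself or would follow from other groups on the same nitrogen, such as an acetyl amide, a urea or a simple methyl. Also open, from the compounds shown here alone, is how much room the position allows, for example with ethylsulfonyl or phenylsulfonyl in place of methylsulfonyl, or with a longer chain than the ethyl linker that carries the methanesulfonamido group.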